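A few compounds are considered here, and "the series" means these few. Any claim that something is new, unique, unknown or untested is made for them only; others in the source may bear on it.

Series readings in an ADME assay on THP-1 cells (Homo sapiens) for cytotoxicity, read by trypan blue exclusion, with a stated time of 24 h; a lower number here means a stronger inhibitor, a higher number a weaker inhibitor:

- compound 1 `N#C[Se]c1ccc(N)cc1`: > 50000 nM (a limit, not a number)
- compound 2 `N#C[Se]Cc1cccc([N+](=O)[O-])c1`: 9320 nM
- compound 3 `N#C[Se]Cc1ccc(Br)cc1`: 28900 nM

Among the measured compounds shown here, only two of the three readings are true numbers. Compound 1 stands at a limit of the assay, > 50000 nM. Compound 2 reads 9320 nM, and compound 3 reads 28900 nM, the higher of the two numbers, with a gap beyond the usual scatter.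

Next in line is compound 4 `Cc1ccc(C[Se]C#N)cc1`, which has methyl in place of bromo on an aromatic carbon, para to a group of 4 heavy atoms: methyl in place of bromo on an aromatic carbon. For the measured compounds named here, no measured pair isolates a single change, so any expectation for this swap rests on compound 3 at 28900 nM as the starting point. The range is kept wide, and its upper end reaches toward the limit seen for compound 1. The expected step is a 1.2-fold lower number from compound 3 to compound 4 (0.06 log units; within the scatter), with no change beyond the scatter anticipated in this assay. For compound 4 the estimated value is 25000 nM, with an expected range of 10000 nM to 50000 nM.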

Compound 4, half-maximal inhibitory concentration: 24000 nM
For compound 4 the middle estimate is 1.0-fold (0.02 log units) above the measured one; the range from low to high includes it.
By their numbers in this assay, from the lowest: compound 2; then compounds 4 and 3 (each within the scatter of the next). At a limit, above all of these: compound 1.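

In this assay, the series now holds a step that isolates a single change: a 1.2-fold lower number from compound 3 to compound 4 (0.08 log units; within the scatter). With methyl in place of bromo on an aromatic carbon, para to a group of 4 heavy atoms, the two readings cannot be told apart, so at this position the exchange of one single-atom substituent for the other leaves the reading within the scatter in this assay. No measurement at hand bears on why these two substituents read alike.

On these data alone, whether this holds for a methoxy group, a carboxylic acid or a longer chain at the same position stays open. Compound 1 and compound 2 each differ from compound 3 in more than one place, and their steps cannot be read.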